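Methoxy in Place of Hydrogen: Outlook for Compound 3

The source may report more compounds than this note shows. Statements on the series, on what has been measured and on what is new or still open speak of the compounds shown alone.

Measured so far:
Compound 1 `c1cncc(N2CCCNCCC2)c1` gives 78% in an assay on HEK293 cells with Neuronal acetylcholine receptor; alpha4/beta2 (Homo sapiens) as the target, read by FLIPR and calcium flux; a higher number here means a larger maximal response, a lower number a smaller maximal response.
Compound 2 `c1ccc2ncc(N3CCCNCC3)cc2c1` gives 33% in this assay.

Compound 1 stands at the higher of the two maximal responses recorded in this assay; compound 2 sits beyond the scatter below it. Within the data shown here, the two compounds differ in more than one place, so no single step is computed between them; their values show only that the larger maximal response belongs to compound 1.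

Compound 3 `COc1cncc(N2CCCNCCC2)c1` has not been measured. Relative to compound 1 it carries methoxy in place of hydrogen on an aromatic carbon. Among the measured compounds shown here, no measured pair isolates a change of this kind, so the expectation rests on the level of compound 1 and on the change itself. A downward step of moderate size from compound 1 to compound 3 is expected, a number 18 percentage points lower from compound 1 to compound 3 (beyond the scatter), likely beyond the scatter, though the uncertainty is wide and a step within the scatter cannot be excluded. Compound 3 is estimated at 60% in this assay, with a range from 35% to 85%.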

Compound 3, largest response reached (reported as efficacy), in percent of the reference or control that the assay uses: 89%
Compound 3: middle estimate off by 29 percentage points, on the low side, outside the stated range (above it).
By their numbers in this assay, from the lowest: compound 2; then compound 1; then compound 3.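

Among these compounds, the pair compound 1 and compound 3 is the first to isolate a single change: in this assay, methoxy in place of hydrogen on an aromatic carbon, two atoms from the ring nitrogen and meta to a group of 8 heavy atoms, gives a number 11 percentage points higher from compound 1 to compound 3 (beyond the scatter), a modest gain. This position therefore accepts a group of 2 heavy atoms with 1 hydrogen-bond acceptor and the maximal response still rises, something compound 1 and compound 2, which differ in more than one place, could not show. No measurement at hand accounts for the direction of this step.

The compounds shown leave open whether the gain is particular to methoxy or would also appear with a longer chain such as ethoxy, with chlorine or with an amine on the same aromatic carbon. They also leave open whether methoxy at a comparable place on the core of compound 2 would move the maximal response in the same direction.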